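The compounds below may be only part of what the source reports. "The series", "measured", "known", "first", "only" and "open" are said of these compounds alone.

Working notes on the series. Compound 1 `CC(C)(O)C(CCC/C=C(\c1ccccc1)c1cccnc1)C(=O)O` gives 37% in a functional assay on the whole organism for inhibition, with Rattus norvegicus as the target, with a stated time of 24 h, at a dose of 1 mg/kg by the oral route; on this read-out higher numbers stand for more inhibition at the one dose given (going by the name of the read-out) and lower numbers for less inhibition; compound 2 `CCOC(=O)CCCC/C=C(\c1ccccc1)c1cccnc1` gives 35% in this assay, and the step of a number 2 percentage points lower from compound 1 to compound 2 (within the scatter) leaves the two within the scatter of each other, so compound 1 is not set apart on the numbers shown. Compound 3 `CC(C)CSC(CCC/C=C(\c1ccccc1)c1cccnc1)C(=O)O` differs from compound 1 by isobutylsulfanyl in place of 1-hydroxy-1-methylethyl on a saturated chain carbon bound to a carbonyl carbon and a saturated chain carbon. Going by the values given here, the only measured step, from compound 1 to compound 2, also reworks the chain end near the carbonyl and moves nothing beyond the scatter, so no step beyond the scatter is expected in this assay from this change either, the estimated step being a number 2 percentage points lower from compound 1 to compound 3 (within the scatter). Compound 3 is therefore estimated at 35%, with a range of 15% to 55%.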

Compound 3, a percentage reported as inhibition, in the whole organism at one dose (the size of the read-out at that dose, not a potency): 8%
Estimate against measurement, compound 3: 27 percentage points above, and the stated range ends above it.
By their numbers in this assay, from the lowest: compound 3; then compounds 2 and 1 (each within the scatter of the next).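

In this assay, going by these compounds alone, the saturated chain carbon bound to a carbonyl carbon and a saturated chain carbon proves sensitive to its substituent: isobutylsulfanyl in place of 1-hydroxy-1-methylethyl gives a number 29 percentage points lower from compound 1 to compound 3 (beyond the scatter), the only step beyond the scatter. The change swaps several features at once, with sulfur entering, oxygen leaving and the hydrogen-bond donors going from 1 to 0. No measurement available here bears on the reason for this step. The compounds shown leave open whether the sulfur or the lost hydroxyl goes with the lower number. An isobutyl group without sulfur, or a hydroxyl-bearing alkylsulfanyl group, on this carbon would separate the two.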